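The source may hold more compounds than are shown below. What is called first, only, known or untested is meant among the compounds shown, and "the series" means these compounds.

In a toxicity assay on HEK-293T cells (Homo sapiens) for inhibition, read by MTT assay, with a stated time of 24 h (a higher number here means that more compound is tolerated, a lower number that less compound is tolerated), three compounds sharing one core have been tested so far. Compound 1, `O=c1oc2ccccc2c(N2CCN(c3cccc(Cl)c3Cl)CC2)c1CO`, gives only a limit, > 50000 nM. Compound 2, `O=c1oc2ccccc2c(N2CCN(c3ccc(F)cc3)CC2)c1CO`, also gives only a limit, > 50000 nM. Compound 3, `O=c1oc2ccccc2c(N2CCN(c3ccc(Cl)c(Cl)c3)CC2)c1CO`, likewise gives only a limit, > 50000 nM. Compound 3 therefore has no exact number, and its position is described by the limit of > 50000 nM in this assay, at which 3 of the 3 values shown sit.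

Compound 4, `COc1ccc(N2CCN(c3c(CO)c(=O)oc4ccccc34)CC2)cc1`, keeps the core of compound 3 but has 4-methoxyphenyl in place of 3,4-dichlorophenyl on an amine nitrogen in a ring.

For the measured compounds named here, three measured steps bear on this swap, as each changes the group at this same place: a step that the two limits leave unreadable from compound 1 to compound 2, a step that the two limits leave unreadable from compound 1 to compound 3 and a step that the two limits leave unreadable from compound 2 to compound 3. None has a readable size, so they point in no direction. Even so, all three groups tried here gave the same limit, and no tested compound goes against that. In this assay, no step beyond the usual scatter is therefore expected, in either direction. The estimated step is a step that the limit leaves unreadable from compound 3 to compound 4. A report of only a limit is again the likeliest outcome. For compound 4, the estimated value is 60000 nM, with an expected range from 25000 nM to 150000 nM.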

Compound 4, half-maximal cytotoxic concentration: > 50000 nM
Compound 4 was reported as a limit; the forecaster's own chance of this, stated with the estimate: 85%; the middle value lies beyond the limit too.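

Compound 4 gives only a limit in this assay, as do compound 1, compound 2 and compound 3, so none of its steps to those three compounds can be read: the limit of > 50000 nM in this assay, at which 4 of the 4 values shown sit.

The compounds shown leave open what concentration of any of them harms these cells, and whether any group at this place on the amine nitrogen would change it.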